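A Chain Methyl on a Compound Held at a Limit

The source may hold more compounds than are shown below. What is called first, only, known or untested is meant among the compounds shown, and "the series" means these compounds.

In a functional assay on the whole organism for antagonist activity, with Mus musculus as the target (on this read-out higher numbers stand for an effect only at larger amounts of compound and lower numbers for an effect already at smaller amounts), compound 1 (`CC(=O)N(C)C(C)C#CCn1cncc1C`) gives 80 mg/kg. Compound 2 (`COC(=O)NCC#CCn1cncc1C`) is recorded only as a limit, > 100 mg/kg. Compound 3 (`COC(=O)N(C)CC#CCn1cncc1C`) is also recorded only as a limit, > 100 mg/kg, so its standing in the series carries no actual number.

Compound 4 (`COC(=O)N(C)C(C)C#CCn1cncc1C`) differs from compound 3 by methyl in place of hydrogen on a saturated chain carbon bound to an amide-type nitrogen and a triple-bonded carbon. Among the measured compounds shown here, the only measured step is a step that the two limits leave unreadable from compound 2 to compound 3. That change lies at a different place, and its size cannot be read, so it offers no magnitude to carry over. Compound 1 already bears a methyl on such a chain carbon and has a numerical value, but it also differs from compound 4 elsewhere, so it is only a loose guide. A modest shift in this assay towards smaller doses is therefore expected, with low confidence, and another limit remains quite possible. The expected change is an at least 1.1-fold lower number from compound 3 to compound 4 (0.07 log units; that floor lies within the scatter). Compound 4 is estimated at 85 mg/kg, with an expected range of 35 mg/kg to 200 mg/kg.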

Compound 4, dose for half-maximal effect: > 100 mg/kg
Compound 4 ended at the assay's limit (the forecaster's own chance of this, stated with the estimate: 50%); middle value at least 1.1-fold (0.07 log units) away from the limit.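

Methyl on the saturated chain carbon leaves compound 4 at a limit of the assay, > 100 mg/kg, not a number, and the steps that join two limits cannot be read. Among the compounds shown here, the one readable comparison keeps the chain methyl on both sides: methoxy in place of methyl on a carbonyl carbon gives an at least 1.2-fold higher number from compound 1 to compound 4 (0.09 log units; that floor lies within the scatter), so even this step does not clearly separate the two. In this assay nearly the whole set therefore gives no numerical value: the limit of > 100 mg/kg in this assay, at which 3 of the 4 values shown sit.

Going by these compounds, whether the chain methyl has any effect remains open, as does the size of the change on the carbonyl carbon. What a longer chain on that chain carbon, or an amine in place of the methoxy, would do in this assay is also left open.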